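Pyridinyl for Fluorophenyl on Two Triazole-Bearing Cores

This account rests on a few compounds, and the source may have more. Where it says the series, first, only, none or still open, it means among the compounds named here.

Three compounds that share a triazole linked to a polycyclic scaffold were tested in a functional assay on A549 cells (Homo sapiens) for cytotoxicity, read by MTT assay, with a stated time of 4 days; on this read-out higher numbers stand for weaker inhibition and lower numbers for stronger inhibition. Compound 1 `C=C1C(=O)[C@]23C[C@@]1(O)CC[C@H]2c1ccc(OS(=O)(=O)c2ccc(C)cc2)c(C)c1[C@@H]3Cn1cc(-c2ccccn2)nn1` gives 2310 nM, and compound 2 `C=C1C(=O)[C@]23C[C@@]1(O)CC[C@H]2c1ccc(OS(=O)(=O)c2ccc(C)cc2)c(C)c1[C@@H]3Cn1cc(-c2ccc(F)cc2)nn1` gives 1950 nM. These two compounds differ in one place only: pyridin-2-yl in place of 4-fluorophenyl on an aromatic carbon. That change made a step of a 1.2-fold higher number from compound 2 to compound 1 (0.07 log units; within the scatter), so on this core the two groups behave the same within the usual scatter.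

Compound 3 `C=C1C[C@]23C[C@@]1(O)CC[C@H]2c1cc(Br)c(O)c(C)c1[C@@H]3Cn1cc(-c2ccc(F)cc2)nn1` is built on a different core and gives 17900 nM in this assay. How the two cores differ is not broken down here; compound 3 and compound 2 differ in more than one place, and only their two values can be compared. On that basis compound 3 stands apart from both of the others by a margin beyond the scatter.

Compound 4 `C=C1C[C@]23C[C@@]1(O)CC[C@H]2c1cc(Br)c(O)c(C)c1[C@@H]3Cn1cc(-c2ccccn2)nn1` has not yet been measured. It carries the same change relative to compound 3 that compound 1 carries relative to compound 2: pyridin-2-yl in place of 4-fluorophenyl on an aromatic carbon. The surroundings of the change are the same in both pairs, so the change is the same. Because the earlier step was a 1.2-fold higher number from compound 2 to compound 1 (0.07 log units; within the scatter), the expectation is a step of similar size, a 1.2-fold higher number from compound 3 to compound 4 (0.07 log units; within the scatter), starting from the value of compound 3. Compound 4 is therefore expected to give about 21000 nM in this assay, most likely falling between 8000 nM and 55000 nM.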

Compound 4, half-maximal inhibitory concentration: > 20000 nM
Compound 4: a limit, no number (the forecaster's own chance of this, stated with the estimate: 15%); the middle value lies beyond the limit too.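

In this assay compound 4 gives > 20000 nM, which is a limit of the assay and not a number. The effect of pyridin-2-yl in place of 4-fluorophenyl on the core of compound 3 can therefore be stated only as a floor: an at least 1.1-fold higher number from compound 3 to compound 4 (0.04 log units; that floor lies within the scatter). This result is compatible with the change carrying over from one core to the other, but it does not show that it does, since the true value of compound 4 could lie well past the limit: the same change on two cores in this assay, a 1.2-fold higher number (0.07 log units; within the scatter) from compound 2 to compound 1 and an at least 1.1-fold higher number (0.04 log units; that floor lies within the scatter) from compound 3 to compound 4; the limit leaves it open whether they differ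

The compounds shown leave open whether another group on the triazole, such as an amine, a carboxylic acid or a longer alkyl chain, would give a step beyond the scatter on either core. On these data alone, compound 2 and compound 3 differ in more than one place, and which of those places goes with the gap between their values also remains open.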